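The compounds below may be only part of what the source reports. "The series", "measured", "known", "first", "only" and "open" are said of these compounds alone.

Compound 1 `NC(=O)/C=C/c1ccncc1-c1ccc2ccccc2c1` in a functional assay on A549 cells (Homo sapiens) for inhibition, read by sulforhodamine B assay, with a stated time of 72 h (a lower number here means a stronger inhibitor of growth, a higher number a weaker inhibitor of growth), gives > 10000 nM, which is a limit of the assay.
Compound 2 `Cn1ccc2cc(-c3cnccc3/C=C/C(=O)O)ccc21` in this assay gives > 10000 nM, again only a limit.
Compound 3 `CNC(=O)CCc1ccncc1-c1ccc2ccccc2c1` in this assay gives 10400 nM.

For the measured compounds named here, compound 3 thus holds the only real number among the three results; the other two sit at the limit of > 10000 nM in this assay, at which 2 of the 3 values shown sit. The step that the limit leaves unreadable from compound 1 to compound 3 is therefore unreadable. Compound 4 `O=C(O)CCc1ccncc1-c1ccc2ccccc2c1` differs from compound 3 by hydroxy in place of methylamino on a carbonyl carbon. Going by the values given here, no measured step in this assay covers this change, so its size cannot be taken from the data. Compound 2, which also carries a carboxy group, reaches only a limit. Compound 4 is therefore expected to remain weak, with a step of a 1.4-fold higher number from compound 3 to compound 4 (0.16 log units; within the scatter) that is likely no larger than the scatter, and a real chance that only a limit is reported. The estimate for compound 4 in this assay is 15000 nM, between 5000 nM and 50000 nM.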

Compound 4, concentration for 50% growth inhibition: > 10000 nM
Compound 4: no number, only a limit; the forecaster's own chance of this, stated with the estimate: 60%; the middle value lies beyond the limit too.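

Compound 4 gives only a limit, so no new step can be read from compound 3 or compound 1 to compound 4. The compounds shown leave open whether hydroxy in place of methylamino on a carbonyl carbon changes the result in this assay at all.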